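The source may report more compounds than this note shows. Statements on the series, on what has been measured and on what is new or still open speak of the compounds shown alone.

Of the compounds shown here, three have so far been measured in a functional assay on BJAB cells (Homo sapiens) for antiproliferative activity, with a stated time of 4 days; a higher number here means that more compound is needed for the effect, a lower number that less compound is needed.

Compound 1 `Cc1nn(-c2nc(-c3ccc(Cl)c(Cl)c3)c(SC(C)C)s2)c(C(=O)O)c1-c1ccc(Cl)cc1`: 2500 nM.
Compound 2 `Cc1oncc1-c1nc(-n2nc(C(=O)O)c(-c3cc(Cl)cc(Cl)c3)c2C)sc1SC(C)C`, for which the assay gives only a limit rather than a number: > 44000 nM.
Compound 3 `COC(=O)c1c(Cc2ccccc2[N+](=O)[O-])c(C)nn1-c1nc(-c2ccc(Cl)c(Cl)c2)c(SC(C)C)s1`: 93000 nM.

Among the numbers shown, compound 1 stands lowest. The nearest number is that of compound 3, which lies far higher, well beyond the scatter of repeated measurements. The remaining value, that of compound 2, is a limit, and the limit of > 44000 nM in this assay, at which 1 of the 3 values shown sits, marks where it sits. Going by the values given here, no two of the measured compounds differ in one place only, so no measured step between them can be drawn.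

Compound 4 `CC(=O)Nc1ccc(-c2c(C)nn(-c3nc(-c4ccc(Cl)c(Cl)c4)c(SC(C)C)s3)c2C(=O)O)cc1` has not yet been measured in this assay. It differs from compound 1 in a single place: acetamido in place of chloro on an aromatic carbon. Among the compounds with values here, the measured compounds offer no step of this kind, so the expectation rests on the value of compound 1 alone. A small to moderate step towards a higher number is expected, a 2.0-fold higher number from compound 1 to compound 4 (0.30 log units; within the scatter), though a result within the scatter of compound 1 would not be surprising. On that footing compound 4 is estimated at 5000 nM in this assay, with a range from 1500 nM to 20000 nM.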

Compound 4, half-maximal effective concentration: 139000 nM
The estimate for compound 4 lay 28-fold (1.44 log units) below the measured number, and the stated range ends below it.
By their numbers in this assay, from the lowest: compound 1; then compounds 3 and 4 (each within the scatter of the next).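

The only single-place step among the compounds shown falls on an aromatic carbon of a six-membered aromatic ring of carbon only, para to a large group, and in this assay it is large: with acetamido in place of chloro, the data show a 56-fold higher number from compound 1 to compound 4 (1.75 log units; beyond the scatter). Going by these compounds alone, no earlier pair differed in one place only, so the values could not be tied to any single position; this pair shows that the value in this assay responds strongly to what this carbon carries, at least for the change from 4-chlorophenyl to 4-acetamidophenyl. The change adds heavy atoms, a hydrogen-bond donor and a hydrogen-bond acceptor, but nothing measured here shows why the step is so large.

As far as these compounds go, a single step cannot separate the contributions of the carbonyl, the amide hydrogen and the added atoms, so it remains open whether a plain amine, a methoxy group or a fluorine on the same carbon would stay close to compound 1 or move as far as compound 4. From the compounds shown here alone, it also remains open whether a step of this size would recur with a different group in place of the 3,4-dichlorophenyl ring or the isopropylthio chain of the shared core.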